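Isoxazole substituent swap: cyclopropyl for isopropyl

The compounds below may be only part of what the source reports. "The series", "measured", "known", "first", "only" and "open" are said of these compounds alone.

Measured so far:
compound 1, `CC(C)c1onc(-c2c(Cl)cccc2Cl)c1COc1ccc(N(C)C(=O)c2cccc(C(=O)O)c2)c(C(F)(F)F)n1`, 55% in a functional assay on HEK293 cells for agonist activity at Bile acid receptor (Homo sapiens), read by a luciferase reporter; a higher number here means a larger maximal response, a lower number a smaller maximal response;
compound 2, `CC(C)c1onc(-c2c(Cl)cccc2Cl)c1COc1ccc(N(C)Cc2cccc(C(=O)O)c2)c(C(F)(F)F)n1`, 58% in this assay.

Compound 2 gives the higher of the two numbers, but only by a number 3 percentage points higher from compound 1 to compound 2 (within the scatter), so the two compounds sit together. Compound 3, `CN(Cc1cccc(C(=O)O)c1)c1ccc(OCc2c(-c3c(Cl)cccc3Cl)noc2C2CC2)nc1C(F)(F)F`, differs from compound 2 by cyclopropyl in place of isopropyl on an aromatic carbon. Among the compounds with values here, no measured step touches this position; the only step known concerns the group on the nitrogen. No shift beyond the scatter is therefore expected, and the estimated step is a number 1 percentage points lower from compound 2 to compound 3 (within the scatter). Compound 3 is expected to give 57% in this assay, within 40% to 74%.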

Compound 3, largest response reached (reported as efficacy), in percent of the reference or control that the assay uses: 43%
The estimate for compound 3 lay 14 percentage points above the measured number, and the stated range covers the measured number.
By their numbers in this assay, from the lowest: compound 3; then compounds 1 and 2 (each within the scatter of the next).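

The carbon next to the ring oxygen is a position where the maximal response moves: in this assay cyclopropyl in place of isopropyl gives a number 15 percentage points lower from compound 2 to compound 3 (beyond the scatter) and thus a larger shift than the change on the nitrogen. Both groups have 3 heavy atoms, all carbon, so heavy-atom count alone does not fix the response here. No measurement at hand explains this drop.

As far as these compounds go, whether tert-butyl or ethyl at this carbon would give a response nearer that of isopropyl or of cyclopropyl remains open. Also open, from the compounds shown here alone, is whether the step repeats with the (3-carboxyphenyl)carbonyl group on the nitrogen.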